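A few compounds are considered here, and "the series" means these few. Any claim that something is new, unique, unknown or untested is made for them only; others in the source may bear on it.

Compound 1 `COC(=O)c1cc(=O)c2cc(NC(=O)Nc3ccc(Cl)c(Cl)c3)ccc2[nH]1`: > 12600 nM
Compound 2 `COC(=O)c1cc(=O)c2cc(NC(=O)Nc3ccc(F)c(Cl)c3)ccc2[nH]1`: > 12600 nM
Compound 3 `COC(=O)c1cc(=O)c2cc(NC(=O)Nc3ccc(C(F)(F)F)cc3[N+](=O)[O-])ccc2[nH]1`: > 51700 nM

Of the compounds shown here, three sharing one core have been tested in an ADME assay on BJ cells (Homo sapiens) for antiproliferative activity, with a stated time of 72 h; a higher number here means that more compound is needed for the effect, a lower number that less compound is needed. For compound 1 the value > 12600 nM is a limit of the assay, not a number. For compound 2 the value > 12600 nM is likewise a limit. For compound 3 the value > 51700 nM is also a limit, though a higher one. Compound 2 thus stands, like every other compound shown, only at a limit; no real number is known for it. Among the measured compounds shown here, the one measured step with a single change, a step that the two limits leave unreadable from compound 1 to compound 2, cannot be read, since both ends are limits.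

Compound 4 `COC(=O)c1cc(=O)c2cc(NC(=O)Nc3cccc(C(C)=O)c3)ccc2[nH]1` has not yet been measured. It differs from compound 2 in one place: 3-acetylphenyl in place of 3-chloro-4-fluorophenyl on an amide-type nitrogen. For the measured compounds named here, no measured step involves the 3-acetylphenyl group, so this change has no direct precedent among the measured compounds. Going by the values given here, what the data offer is the limit of > 12600 nM in this assay, at which 2 of the 3 values shown sit, and (the limit of > 51700 nM in this assay, at which 1 of the 3 values shown sits), which show that every compound so far sits at a limit. Compound 4 is therefore expected to sit at a limit as well, with an estimate of 20000 nM in this assay and a range from 8000 nM to 60000 nM. The expected step that the limit leaves unreadable from compound 2 to compound 4 is estimated as none beyond the scatter.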

Compound 4, half-maximal effective concentration: > 16000 nM
Compound 4 gave a limit, no number; the forecaster's own chance of this, stated with the estimate: 80%; the middle value lies beyond the limit too.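

In this assay compound 4 gives > 16000 nM, which is a limit and not a number. The steps from compound 1 and from compound 2 to compound 4 cannot be read: both ends of each are limits. The compounds shown leave open the real value of each one in this assay, and with it whether changing the group on the amide-type nitrogen makes any difference.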